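From 4-chlorophenyl to 3,4-dimethoxyphenyl on the shared core

The compounds below may be only part of what the source reports. "The series", "measured", "known", "first", "only" and "open" are said of these compounds alone.

Three compounds share a core and differ only in the aryl group attached to a nitrogen on an aromatic ring. In a functional assay on PC-3 cells (Homo sapiens) for cytotoxicity, read by MTT assay, with a stated time of 72 h (a lower number here means a stronger inhibitor, a higher number a weaker inhibitor), compound 1 `O=[N+]([O-])c1cccc(Nc2nc(SCc3ccc(C(F)(F)F)cc3)nc3ccccc23)c1` gives 13500 nM, compound 2 `Fc1ccc(Nc2nc(SCc3ccc(C(F)(F)F)cc3)nc3ccccc23)cc1` gives 7070 nM, and compound 3 `FC(F)(F)c1ccc(CSc2nc(Nc3ccc(Cl)cc3)c3ccccc3n2)cc1` gives 7110 nM. Compound 3 stands second highest of the three numbers, with compound 2 as its nearest neighbour and compound 1 furthest away, yet all three lie within the usual scatter of one another.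

Compound 4 `COc1ccc(Nc2nc(SCc3ccc(C(F)(F)F)cc3)nc3ccccc23)cc1OC` carries the change (3,4-dimethoxyphenyl in place of 4-chlorophenyl on a nitrogen on an aromatic ring). The measured steps that touch this position are a 1.9-fold lower number from compound 1 to compound 2 (0.28 log units; within the scatter), a 1.9-fold lower number from compound 1 to compound 3 (0.28 log units; within the scatter) and a 1.0-fold higher number from compound 2 to compound 3 (0.00 log units; within the scatter), none of which moved this assay beyond its scatter. Among the compounds with values here, no measured step introduces a 3,4-dimethoxyphenyl group, so the expectation for compound 4 rests on these small movements: a step of a 1.1-fold higher number from compound 3 to compound 4 (0.02 log units; within the scatter) is expected, with no clear direction. Compound 4 is therefore estimated at 7500 nM, within a range from 2500 nM to 22000 nM.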

Compound 4, half-maximal inhibitory concentration: 14100 nM
Estimate against measurement, compound 4: 1.9-fold (0.27 log units) below, within the range that was stated.
By their numbers in this assay, from the lowest: compounds 2, 3, 1 and 4 (each within the scatter of the next).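

In this assay, 3,4-dimethoxyphenyl in place of 4-chlorophenyl gives a 2.0-fold higher number from compound 3 to compound 4 (0.30 log units; within the scatter) and in place of 4-fluorophenyl gives a 2.0-fold higher number from compound 2 to compound 4 (0.30 log units; within the scatter), so even this different substitution pattern does not clearly move the number at this position. Set against the 3-nitrophenyl group, it gives a 1.0-fold higher number from compound 1 to compound 4 (0.02 log units; within the scatter), which means that all four aryl groups on this nitrogen remain within the scatter of one another and cannot yet be told apart here. Nothing measured alongside these numbers offers an explanation for them.

Still open, on these data alone, is whether any group on this nitrogen can shift the number beyond the scatter, or whether an aromatic ring is needed there at all. A cyclohexyl group, or a phenyl ring carrying a carboxylic acid or a dimethylamino group, would put both questions to the test.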